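The source may report more compounds than this note shows. Statements on the series, on what has been measured and on what is new or still open speak of the compounds shown alone.

Among the compounds with values here, compound 2 `COc1ccc(Cn2cc(CNC(=O)c3cn(-c4ccccc4)nc3-c3ccc(OC)cc3)nn2)cc1` stands lowest of the two numbers so far: in a functional assay on HeLa cells (Homo sapiens) for antiproliferative activity, read by sulforhodamine B assay, with a stated time of 48 h (a lower number here means a stronger inhibitor of growth, a higher number a weaker inhibitor of growth), compound 2 gives 450 nM. Compound 1 `COc1cc(Cn2cc(CNC(=O)c3cn(-c4ccccc4)nc3-c3ccccc3)nn2)cc(OC)c1` gives 12200 nM in this assay, a far higher number, though it differs from compound 2 in two places. Compound 3 `COc1ccc(-c2nn(-c3ccccc3)cc2C(=O)NCc2cn(Cc3cc(OC)cc(OC)c3)nn2)cc1` is compound 2 with a single change: 3,5-dimethoxyphenyl in place of 4-methoxyphenyl on a saturated chain carbon bound to an aromatic nitrogen. Compound 1 carries this same 3,5-dimethoxybenzyl group, so a shift toward weaker growth inhibition is expected, but only a modest one, because compound 1 at 12200 nM also lacks the 4-methoxyphenyl group. The expected step of a 3.3-fold higher number from compound 2 to compound 3 (0.52 log units; beyond the scatter) puts compound 3 at an estimated 1500 nM, within 400 nM to 6000 nM.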

Compound 3, concentration for 50% growth inhibition: 12400 nM
Estimate against measurement, compound 3: 8.3-fold (0.92 log units) below; measured number above the stated range.
By their numbers in this assay, from the lowest: compound 2; then compounds 1 and 3 (each within the scatter of the next).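

In this assay, the benzyl group alone is enough to weaken growth inhibition: 3,5-dimethoxybenzyl in place of 4-methoxybenzyl gives a 28-fold higher number from compound 2 to compound 3 (1.44 log units; beyond the scatter). With 3,5-dimethoxybenzyl present, methoxy in place of hydrogen on an aromatic carbon gives a 1.0-fold higher number from compound 1 to compound 3 (0.01 log units; within the scatter), so this added methoxy makes no measurable difference here. No available evidence explains either result. Still open, on these data alone, is how a plain benzyl or a 4-chlorobenzyl would read at this place. Also open, as far as these compounds go, is whether that methoxy matters as little when 4-methoxybenzyl is present.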